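1H-indol-4-yl in place of 1H-indol-5-yl: working notes

A few compounds are considered here, and "the series" means these few. Any claim that something is new, unique, unknown or untested is made for them only; others in the source may bear on it.

Three measured compounds differ only in the aryl group on the sulfonyl sulfur: compound 1 (`Cn1c(=O)c(S(=O)(=O)c2ccc(Cl)cc2Cl)cc2cnc(Nc3ccc4[nH]ccc4c3)nc21`), compound 2 (`Cn1c(=O)c(S(=O)(=O)c2ccc(F)cc2)cc2cnc(Nc3ccc4[nH]ccc4c3)nc21`) and compound 3 (`Cn1c(=O)c(S(=O)(=O)c2ccc(N)cc2F)cc2cnc(Nc3ccc4[nH]ccc4c3)nc21`). In a functional assay on K562 cells (Homo sapiens) for inhibition, read by trypan blue exclusion, with a stated time of 72 h (a higher number here means a weaker inhibitor, a lower number a stronger inhibitor), compound 2 gives 200 nM as the lowest of the three numbers, while compound 1 gives 1000 nM and compound 3 gives 1500 nM in this series. The last two lie within the scatter of each other (a 1.5-fold higher number from compound 1 to compound 3 (0.18 log units; within the scatter)).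

Compound 4 (`Cn1c(=O)c(S(=O)(=O)c2ccc(F)cc2)cc2cnc(Nc3cccc4[nH]ccc34)nc21`) keeps the 4-fluorophenyl of compound 2 and differs in one place (1H-indol-4-yl in place of 1H-indol-5-yl on a nitrogen on an aromatic ring): 1H-indol-4-yl in place of 1H-indol-5-yl on a nitrogen on an aromatic ring. Going by the values given here, no measured step touches this group. The nearest guides are the modest steps at the sulfonyl sulfur (a 5.0-fold lower number from compound 1 to compound 2 (0.70 log units; beyond the scatter)) and (a 7.5-fold higher number from compound 2 to compound 3 (0.88 log units; beyond the scatter)), which show only how far a single change has moved the number in this small set.

Among the compounds with values here, since compound 2 holds the lowest number so far, a modest rise is more likely than a further fall, though direct evidence is lacking. The expected change is of similar or smaller size (a 2.5-fold higher number from compound 2 to compound 4 (0.40 log units; beyond the scatter)). For compound 4 the estimated value is 500 nM in this assay, with an expected range from 120 nM to 2500 nM as the outer ends.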

Compound 4, half-maximal inhibitory concentration: 750 nM
Compound 4: middle estimate off by 1.5-fold (0.18 log units), on the low side; low and high end bracket the measured number.
By their numbers in this assay, from the lowest: compound 2; then compounds 4, 1 and 3 (each within the scatter of the next).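

Moving the attachment point on the indole is the first change here outside the aryl group on the sulfonyl sulfur, and 1H-indol-4-yl in place of 1H-indol-5-yl on a nitrogen on an aromatic ring gives a 3.8-fold higher number from compound 2 to compound 4 (0.57 log units; beyond the scatter) in this assay. The two groups have the same atoms joined differently, so this position responds to the point of attachment alone, and the step is of the same modest class as those at the sulfonyl sulfur, a 5.0-fold lower number from compound 1 to compound 2 (0.70 log units; beyond the scatter) and a 7.5-fold higher number from compound 2 to compound 3 (0.88 log units; beyond the scatter), with compound 2 still the strongest inhibitor of the four. No measurement shown here accounts for the rise in the number, so the step stands as an observation only.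

On these data alone, it remains open whether the same indole change has a step of similar size when the 2,4-dichlorophenyl of compound 1 or the 4-amino-2-fluorophenyl of compound 3 sits on the sulfonyl sulfur. Also open, as far as these compounds go, is how the number responds at this nitrogen to groups other than these two indoles, such as a phenyl ring carrying a morpholine or a longer amine chain.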